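Butyl in Place of 3-Chlorophenyl on the Sulfonyl Sulfur

The source may report more compounds than this note shows. Statements on the series, on what has been measured and on what is new or still open speak of the compounds shown alone.

The series was examined in a functional assay on RH7777 cells for antagonist activity at lysophosphatidic acid receptor 2 (Homo sapiens), read by calcium flux; a lower number here means a stronger inhibitor, a higher number a weaker inhibitor. Compound 1 `Cc1noc(-c2ccccc2)c1NC(=O)OC(C)c1ccccc1` gave no number: in this assay compound 1 sits at the limit > 50000 nM. Compound 3 `COc1ccccc1N1CCN(CCNc2nc(C(F)(F)F)nc3ccccc23)CC1` also gave only a limit, recorded for compound 3 as > 30000 nM. For the measured compounds named here, compound 2 `Cc1csc2c(N[C@@H](C)CN3CCN(S(=O)(=O)c4cccc(Cl)c4)CC3)ncnc12` is therefore the one compound of the set with a measured value, and in this assay compound 2 gives 35 nM. Where compound 2 stands is thus simple to state: it holds the only number, while the other two entries are limits the limit of > 30000 nM in this assay, at which 1 of the 3 values shown sits, and (the limit of > 50000 nM in this assay, at which 1 of the 3 values shown sits).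

Compound 4 `CCCCS(=O)(=O)N1CCN(C[C@H](C)Nc2ncnc3c(C)csc23)CC1` is the untested partner of compound 2. Counted from the two structures, the change is butyl in place of 3-chlorophenyl on a sulfonyl sulfur.

Going by the values given here, no measured pair in this set shares that kind of change, so the expectation for compound 4 rests on the anchor value of compound 2 alone. The author expects the step in this assay to run toward weaker inhibition and to exceed the usual scatter, a 4.3-fold higher number from compound 2 to compound 4 (0.63 log units; beyond the scatter). Compound 4 is accordingly estimated at 150 nM, with a likely range from 35 nM to 900 nM.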

Compound 4, half-maximal inhibitory concentration: 6610 nM
Beside the measured number, compound 4's estimate is 44-fold (1.64 log units) below it; the measured number lies above the stated range.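

In this assay, for the compounds shown here, the step on the sulfonyl sulfur is a 190-fold higher number from compound 2 to compound 4 (2.28 log units; beyond the scatter) and it is the first comparison in this set between two compounds that differ in one place, which the earlier compounds, with no such pair among them, could not offer. It shows that this position is far from indifferent to the group it carries: with the rest of the molecule held constant, butyl retains only a small part of the inhibition seen with 3-chlorophenyl, although compound 4 still gives a measured number and not a limit. Nothing measured here accounts for the size of this step.

The compounds shown leave open whether the difference follows the ring or the chlorine, a question that plain phenyl on the same sulfur would help to separate. They also leave open how far the chain itself matters, as methyl, a longer chain such as hexyl, or a cyclohexyl ring in place of butyl could show.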